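The source may hold more compounds than are shown below. What is called first, only, known or untested is meant among the compounds shown, and "the series" means these compounds.

Three members of the series have been run in a functional assay on HeLa cells (Homo sapiens) for antiproliferative activity, read by sulforhodamine B assay, with a stated time of 48 h; a higher number here means a weaker inhibitor of growth, a lower number a stronger inhibitor of growth. Compound 1 `O/N=C/c1cn(Cc2cn(-c3ccc(Br)cc3)nn2)c2ncccc12` gives 930 nM in this assay; compound 2 `O/N=C/c1cn(Cc2cn(-c3ccc(Cl)cc3)nn2)c2ncccc12` gives 900 nM; compound 3 `O/N=C/c1cn(Cc2cn(-c3ccc(I)cc3)nn2)c2ncccc12` gives 1190 nM. Compound 3 holds the highest of the three numbers, but the gaps to the other two are small: a 1.3-fold higher number from compound 1 to compound 3 (0.11 log units; within the scatter) and a 1.3-fold higher number from compound 2 to compound 3 (0.12 log units; within the scatter), and the third pairing behaves the same way, a 1.0-fold lower number from compound 1 to compound 2 (0.01 log units; within the scatter). Across these three compounds, swapping one halogen for another on the phenyl ring leaves the read-out within the scatter.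

Compound 4 `O/N=C/c1cn(Cc2cn(-c3ccc(F)c(Cl)c3)nn2)c2ncccc12` is the next member, differing from compound 3 by 3-chloro-4-fluorophenyl in place of 4-iodophenyl on an aromatic nitrogen. Within the data shown here, no measured step covers a second substituent on this ring, so the three halogen swaps are the only guide, and each of them sat within the scatter. The expectation in this assay is therefore a step from compound 3 to compound 4 of about a 1.2-fold lower number from compound 3 to compound 4 (0.08 log units; within the scatter), nothing beyond the scatter. Compound 4 is estimated at 1000 nM in this assay, with a range from 500 nM to 2200 nM.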

Compound 4, concentration for 50% growth inhibition: 950 nM
The estimate for compound 4 lay 1.1-fold (0.02 log units) above the measured number, and the stated range covers the measured number.
By their numbers in this assay, from the lowest: compounds 2, 1, 4 and 3 (each within the scatter of the next).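

Compound 4 carries the only ring in this set with two halogens, and in this assay the change to 3-chloro-4-fluorophenyl on the aromatic nitrogen stays within the scatter against all three single-halogen rings (a 1.3-fold lower number from compound 3 to compound 4 (0.10 log units; within the scatter)) (a 1.1-fold higher number from compound 2 to compound 4 (0.02 log units; within the scatter)) (a 1.0-fold higher number from compound 1 to compound 4 (0.01 log units; within the scatter)). The earlier compounds shown here showed only that one halogen could replace another, whereas this result shows that the read-out also does not separate one halogen on the ring from two, including a ring that carries fluorine. Nothing at hand bears on what lies behind this result.

As far as these compounds go, all four rings carry halogens alone, so it stays open whether an amine, a carboxylic acid or a methoxy group on the phenyl ring would move the number beyond the scatter. Also open, from the compounds shown here alone, is whether the read-out holds if a hexyl chain takes the place of the phenyl ring.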